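From butylsulfanyl to benzylsulfanyl on a shared core

The source may report more compounds than this note shows. Statements on the series, on what has been measured and on what is new or still open speak of the compounds shown alone.

The study follows one shared core, carrying a dithioester and an arylamine, through a functional assay on PBMC cells (Homo sapiens) for inhibition, read by ELISA, with a stated time of 18 h; on this read-out lower numbers stand for stronger inhibition and higher numbers for weaker inhibition. Compound 1 `CCCCSC(=S)C1=C(Nc2ccc(Cl)cc2Cl)CC(C)(C)CC1=O` bears a butylsulfanyl dithioester and two chloro groups on aromatic carbons. In this assay compound 1 gives only a limit, > 20 ug/mL. Compound 2 `CC1(C)CC(=O)C=C(Nc2ccc(Cl)cc2)C1` lacks the dithioester altogether. In this assay compound 2 likewise gives only a limit, > 20 ug/mL. Compound 3 `CCCCSC(=S)C1=C(Nc2ccc(Cl)cc2)CC(C)(C)CC1=O` carries the butylsulfanyl dithioester and one chloro on an aromatic carbon. In this assay compound 3 too reaches only a limit, > 20 ug/mL. Both steps that lead to compound 3 are therefore unreadable, a step that the two limits leave unreadable from compound 1 to compound 3 and a step that the two limits leave unreadable from compound 2 to compound 3, since every value shown sits at the limit of > 20 ug/mL in this assay, at which 3 of the 3 values shown sit.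

Compound 4 `CC1(C)CC(=O)C(C(=S)SCc2ccccc2)=C(Nc2ccc(Cl)cc2)C1` differs from compound 3 in one place: phenyl in place of propyl on a saturated chain carbon bound to a sulfur. For the measured compounds named here, no measured step bears on this change, and nothing among the three values places compound 3 at a number rather than at a limit. The expectation for compound 4 rests on that limit alone. The step is therefore expected to read a step that the limit leaves unreadable from compound 3 to compound 4. Compound 4 is estimated at 25 ug/mL, within 8 ug/mL to 80 ug/mL, most likely reported again only as a limit.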

Compound 4, half-maximal inhibitory concentration: > 20 ug/mL
Compound 4 ended at the assay's limit; the forecaster's own chance of this, stated with the estimate: 75%; the middle value lies beyond the limit too.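

In this assay, for the compounds shown here, compound 4 also gives only a limit, > 20 ug/mL as its sole reading. No new step can be read from compound 3 to compound 4, and all the values shown stand at one limit: the limit of > 20 ug/mL in this assay, at which 4 of the 4 values shown sit. The compounds shown leave open how far any of them lies beyond that limit, and whether any change among them alters inhibition.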